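The source may report more compounds than this note shows. Statements on the series, on what has been measured and on what is new or still open speak of the compounds shown alone.

Working notes on the series.

Compound 1 `CCc1ccc2[nH]c(=O)c(CN(Cc3ccc(C(C)(C)C)cc3)C(C)c3ccc(F)cc3)cc2c1` gives 2800 nM in a toxicity assay on MDCK cells (Canis lupus familiaris) for cytotoxicity, read by crystal violet staining, with a stated time of 48 h; a lower number here means that less compound is tolerated, a higher number that more compound is tolerated. Compound 2 `CC(C)c1ccc2[nH]c(=O)c(CN(Cc3ccc(C(C)(C)C)cc3)C(C)c3ccc(F)cc3)cc2c1` differs from it only by methyl in place of hydrogen on a saturated chain carbon bound to an aromatic carbon and a saturated chain carbon; in this assay compound 2 gives 13100 nM, which is a 4.7-fold higher number from compound 1 to compound 2 (0.67 log units; beyond the scatter).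

Compound 3 `COc1ccc(C(C)N(Cc2ccc(C(C)(C)C)cc2)Cc2cc3cc(C)ccc3[nH]c2=O)cc1Cl` carries a different core; the difference between the core of compound 3 and the core of compound 1 is not broken down here. For compound 3 this assay reports only a limit, > 10000 nM. That limit is the limit of > 10000 nM in this assay, at which 1 of the 3 values shown sits.

Compound 4 `CCc1ccc2[nH]c(=O)c(CN(Cc3ccc(C(C)(C)C)cc3)C(C)c3ccc(OC)c(Cl)c3)cc2c1` stands to compound 3 as compound 2 stands to compound 1: the change is methyl in place of hydrogen on a saturated chain carbon bound to an aromatic carbon. The two places are not identical in wording: in compound 1 the carbon is bound to an aromatic carbon and a saturated chain carbon, whereas in compound 3 it is bound to an aromatic carbon only, so this is the same kind of change rather than the same change. Cut one bond further out, the earlier step reads ethyl to isopropyl and the present one methyl to ethyl.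

The earlier step of a 4.7-fold higher number from compound 1 to compound 2 (0.67 log units; beyond the scatter) raised the number beyond the scatter, and compound 3 already sits at a limit. Compound 4 is therefore expected to give 20000 nM in this assay, with the range 8000 nM to 60000 nM. The step this expectation implies, a step that the limit leaves unreadable from compound 3 to compound 4, rests on the direction of a 4.7-fold higher number from compound 1 to compound 2 (0.67 log units; beyond the scatter) and on the starting limit of compound 3; a further limit rather than a number is the likelier outcome.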

Compound 4, half-maximal cytotoxic concentration: > 10000 nM
Compound 4 was reported as a limit (the forecaster's own chance of this, stated with the estimate: 70%); the middle value does not contradict the limit.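

In this assay, compound 3 and compound 4 both stand at a limit rather than at a number, so the change of methyl in place of hydrogen on a saturated chain carbon bound to an aromatic carbon cannot be read on this core, and no size or direction can be given for it: the limit of > 10000 nM in this assay, at which 2 of the 4 values shown sit.

Among these compounds, the step on the core of compound 1, a 4.7-fold higher number from compound 1 to compound 2 (0.67 log units; beyond the scatter), is therefore neither confirmed nor contradicted on the core of compound 3, and the two limits show only that the ethyl compound 4 stays at the same limit as the methyl compound 3. Among the compounds shown here, the one step that can be read is an at least 3.5-fold higher number from compound 1 to compound 4 (0.55 log units; beyond the scatter), but it belongs to a different change, 3-chloro-4-methoxyphenyl in place of 4-fluorophenyl on a saturated chain carbon bound to an amine nitrogen and a saturated chain carbon, and it says nothing about whether the methyl change carries from one core to another.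

As far as these compounds go, whether the methyl change moves the number on the core of compound 3 in the same direction as on the core of compound 1 stays open, since both values there are limits. Also open, from the compounds shown here alone, is how a longer chain such as butyl, or a carboxylic acid in place of the ethyl, would read in this assay.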